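Aryl swap at the benzylic carbon of compound 3

The source may hold more compounds than are shown below. What is called first, only, known or untested is meant among the compounds shown, and "the series" means these compounds.

Compound 3 `O=C(O)CCc1ccc(NCc2ccc(Cl)s2)cc1` stands highest of the three numbers measured in a functional assay on CHO cells for agonist activity at Free fatty acid receptor 1 (Homo sapiens), read by reporter gene assay; a lower number here means a smaller maximal response, a higher number a larger maximal response: compound 3 gives 143%, compound 1 `O=C(O)CCCc1ccc(NCc2cccc(Oc3ccccc3)c2)cc1` gives 74% and compound 2 `CC(C(=O)O)c1ccc(NCc2cccc(Oc3ccccc3)c2)cc1` gives 34%. Going by the values given here, the one measured step that differs in a single place, a number 40 percentage points lower from compound 1 to compound 2 (beyond the scatter), concerns the acid-bearing chain and not the aryl group on the carbon bound to the ring nitrogen. Compound 4 `O=C(O)CCc1ccc(NCc2cccnc2)cc1` differs from compound 3 by pyridin-3-yl in place of 5-chlorothiophen-2-yl on a saturated chain carbon bound to a nitrogen on an aromatic ring. Among the compounds with values here, no measured step touches this place, so nothing measured bears on it directly; compound 1 and compound 3 differ in two places and only their two values can be compared. The expectation for compound 4 therefore rests on compound 3 alone, with wide uncertainty, and a step of a number 43 percentage points lower from compound 3 to compound 4 (beyond the scatter) downward is expected as the more likely outcome in this assay. Compound 4 is estimated at 100%, within a range from 45% to 150%.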

Compound 4, largest response reached (reported as percent of maximum), in percent of the reference or control that the assay uses: 4%
Compound 4: the middle estimate sits 96 percentage points above what was measured; measured number below the stated range.
By their numbers in this assay, from the lowest: compound 4; then compound 2; then compound 1; then compound 3.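

In this assay, the aryl group on a saturated chain carbon bound to a nitrogen on an aromatic ring proves decisive for the maximal response: a number 139 percentage points lower from compound 3 to compound 4 (beyond the scatter), larger than the step seen earlier at the acid-bearing chain. The change keeps the heavy-atom count, the hydrogen-bond donor and acceptor counts and the net charge, so these counts do not separate 5-chlorothiophen-2-yl from pyridin-3-yl; what differs is the ring size and the hetero atoms, including the chlorine. No measurement available here accounts for the drop.

Still open, going by these compounds, is which of these differences matters, and a phenyl or an unsubstituted thiophen-2-yl at this place would help separate them. Also open, on these data alone, is whether the step holds when the acid-bearing chain is 3-carboxypropyl or 1-carboxyethyl.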